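Amide aryl variation on the shared core: toward compound 3

A few compounds are considered here, and "the series" means these few. Any claim that something is new, unique, unknown or untested is made for them only; others in the source may bear on it.

Compound 1 `O=C(CSc1nc(Nc2ccccc2)c2ccccc2n1)Nc1ccccc1Br` carries a 2-bromophenyl on the amide-type nitrogen of the shared core. In a functional assay on MGC-803 cells (Homo sapiens) for inhibition, read by MTT assay, with a stated time of 72 h (on this read-out lower numbers stand for stronger inhibition and higher numbers for weaker inhibition), compound 1 gives 18600 nM, the only number shown in this series so far. Compound 2 `O=C(CSc1nc(Nc2ccccc2)c2ccccc2n1)Nc1ccc(F)cc1`, with 4-fluorophenyl in the same place, returns only a limit of the assay in this assay, > 50000 nM. The step of an at least 2.6-fold higher number from compound 1 to compound 2 (0.42 log units; beyond the scatter) is therefore known only as a lower bound, because of the limit of > 50000 nM in this assay, at which 1 of the 2 values shown sits.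

Compound 3 `O=C(CSc1nc(Nc2ccccc2)c2ccccc2n1)Nc1ccc(F)c(Cl)c1` differs from compound 1 by 3-chloro-4-fluorophenyl in place of 2-bromophenyl on an amide-type nitrogen. Within the data shown here, the one measured step that bears on this change, from 2-bromophenyl to 4-fluorophenyl, already went toward weaker inhibition, and compound 3 keeps the fluorine of compound 2 while adding a chlorine. A step of similar size, toward a higher number, is expected for a 1.7-fold higher number from compound 1 to compound 3 (0.24 log units; within the scatter), with a real chance that this assay again reports only a limit. Compound 3 is expected to give about 32000 nM, within 12000 nM to 70000 nM.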

Compound 3, half-maximal inhibitory concentration: 20900 nM
Beside the measured number, compound 3's estimate is 1.5-fold (0.19 log units) above it; the range from low to high includes it.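

The step of a 1.1-fold higher number from compound 1 to compound 3 (0.05 log units; within the scatter) leaves 3-chloro-4-fluorophenyl and 2-bromophenyl on the amide-type nitrogen indistinguishable in this assay, so a halogenated phenyl at this place need not fall to the limit seen for compound 2. Chloro in place of hydrogen on an aromatic carbon does matter on the 4-fluorophenyl group, with an at least 2.3-fold lower number from compound 2 to compound 3 (0.37 log units; beyond the scatter). The true size of that step stays unknown, because compound 2 gives only a limit of the assay: the limit of > 50000 nM in this assay, at which 1 of the 3 values shown sits.

The compounds shown leave open whether the chloro group alone, without the fluorine, would give a similar reading. They also leave open whether an amine or a carboxylic acid on this phenyl ring, or a longer chain in its place on the amide-type nitrogen, would give a lower number.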